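The source may hold more compounds than are shown below. What is called first, only, known or untested is meant among the compounds shown, and "the series" means these compounds.

Within an assay on HEK-293T cells for displacement of a labelled ligand from corticotropin-releasing factor receptor 1 (Homo sapiens), read by scintillation counting, with a stated time of 2 h (a lower number here means a stronger inhibitor, a higher number a weaker inhibitor), compound 3 `CCCCN(CC)c1cc(C)nc2c1NC(=O)CN2c1ccc(Cl)cc1Cl` gives 3.4 nM, the second highest of the three numbers so far. Compound 1 `CCCCN(CC)c1cc(C)nc2c1NC(=O)CN2c1ccc(C)cc1Cl` gives 4.4 nM, the step of a 1.3-fold lower number from compound 1 to compound 3 (0.11 log units; within the scatter) lying within the scatter, while compound 2 `CCCCN(CC)c1cc(C)nc2c1NC(=O)CN2c1ccc(Br)cc1Br` gives 1.3 nM, the step of a 2.6-fold higher number from compound 2 to compound 3 (0.42 log units; beyond the scatter) lying beyond it. Compound 4 `CCCCN(CC)c1cc(C)nc2c1NC(=O)CN2c1ccc(Cl)cc1C` differs from compound 3 by methyl in place of chloro on an aromatic carbon, on an aromatic carbon ortho to a large group and meta to a chloro group; cut one bond further out, 2,4-dichlorophenyl becomes 4-chloro-2-methylphenyl. Among the measured compounds shown here, the one measured exchange of methyl and chloro on this ring, a 1.3-fold lower number from compound 1 to compound 3 (0.11 log units; within the scatter), stayed within the scatter; the halogen-for-halogen steps a 3.4-fold lower number from compound 1 to compound 2 (0.53 log units; beyond the scatter) and a 2.6-fold higher number from compound 2 to compound 3 (0.42 log units; beyond the scatter) were modest. A step within the scatter is therefore expected, a 1.3-fold higher number from compound 3 to compound 4 (0.12 log units; within the scatter). Compound 4 is estimated at 4.5 nM, range 1.8 nM to 12 nM.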

Compound 4, inhibition constant: 5.4 nM
Beside the measured number, compound 4's estimate is 1.2-fold (0.08 log units) below it, and the stated range covers the measured number.
By their numbers in this assay, from the lowest: compound 2; then compounds 3, 1 and 4 (each within the scatter of the next).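

Methyl and chloro on the aromatic carbon ortho to a large group read alike in this assay, with a 1.6-fold higher number from compound 3 to compound 4 (0.20 log units; within the scatter). Exchanging the places of methyl and chloro on the ring also stays within the scatter, with a 1.2-fold higher number from compound 1 to compound 4 (0.09 log units; within the scatter). The 2,4-dibromophenyl group of compound 2 stands apart, with a 4.2-fold higher number from compound 2 to compound 4 (0.62 log units; beyond the scatter).

Nothing shown accounts for these readings. Open, from the compounds shown here alone, are how a fluoro, methoxy or nitrile group would read on this carbon, and whether one bromo alone would match compound 2.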